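A Pyridyl Ring in Place of a Difluorophenyl Ring

The source may report more compounds than this note shows. Statements on the series, on what has been measured and on what is new or still open speak of the compounds shown alone.

Of the compounds shown here, two have been measured in an in vitro assay on HEK385-7 cells for displacement of a labelled ligand from prostaglandin D2 receptor 2 (Homo sapiens); a higher number here means a weaker inhibitor, a lower number a stronger inhibitor. Compound 1, `O=C(O)Cc1sc(C(c2ccccc2)c2ccccn2)nc1-c1ccc(Cl)cc1`, gives 810 nM. Compound 2, `O=C(O)Cc1sc(C(c2ccc(F)cc2)c2ccc(F)cc2)nc1-c1cc(F)cc(F)c1`, gives 35 nM, the lower of the two numbers and thus the stronger inhibitor; its gap to compound 1 lies beyond the usual scatter of repeated measurements. Compound 3, `O=C(O)Cc1sc(C(c2ccc(F)cc2)c2ccc(F)cc2)nc1-c1ccncc1`, has not yet been measured. It differs from compound 2 in one place: pyridin-4-yl in place of 3,5-difluorophenyl on an aromatic carbon. The ring that leaves carries two fluorine atoms and no hetero atom, while the ring that enters brings one nitrogen and one hydrogen-bond acceptor. Among the compounds with values here, no pair of measured compounds differs by just this change, so the size of the step cannot be read from the data. Since the only strong inhibitor known here, compound 2 with 35 nM, carries the fluorinated ring, a loss of potency is expected, of moderate size and beyond the scatter. Compound 3 is therefore expected to give about 200 nM, within a range of 50 nM to 800 nM. The expected step of a 5.7-fold higher number from compound 2 to compound 3 (0.76 log units; beyond the scatter) thus points upward, toward a weaker inhibitor.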

Compound 3, half-maximal inhibitory concentration: 5.3 nM
Compound 3: the middle estimate sits 38-fold (1.58 log units) above what was measured; the whole stated range lies above it.
By their numbers in this assay, from the lowest: compound 3; then compound 2; then compound 1.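

In this assay, the step of a 6.6-fold lower number from compound 2 to compound 3 (0.82 log units; beyond the scatter) shows that this position, on the aromatic carbon next to the ring nitrogen, does not depend on the two fluorine atoms or on a ring of carbon only. A six-membered ring with one nitrogen and one hydrogen-bond acceptor is not merely tolerated here, since pyridin-4-yl gives the stronger inhibitor even though it is the smaller group by heavy-atom count. Within the data shown here, this is also the first clean reading of this position, as compound 1 and compound 2 differ in more than one place and their gap cannot be assigned to any single change. No measurement at hand explains why the change strengthens inhibition.

Among these compounds, with only this one pair, the removal of the two fluorine atoms and the arrival of the nitrogen cannot be told apart, so the share of each in the step remains unknown. A plain phenyl ring at this position would address that question, while a pyrimidine ring, with a second ring nitrogen, would show whether adding more nitrogen takes the trend further.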